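Ethyl to 1,1-Difluoroethyl: a Step Awaiting Measurement

A few compounds are considered here, and "the series" means these few. Any claim that something is new, unique, unknown or untested is made for them only; others in the source may bear on it.

Compound 2 `CCc1ncncc1-c1nc2cc(F)c(F)cc2n1C1CC1` has been tested in an assay on cells for inhibition of cytochrome P450 11B2, mitochondrial (Homo sapiens), read by HPLC, with a stated time of 90 min (a higher number here means a weaker inhibitor, a lower number a stronger inhibitor), where compound 2 gives 8 nM. Within the data shown here, that is the only actual number in the set. Compound 1 `Fc1ccc2nc(-c3cnco3)n(C3CC3)c2c1` reaches only the limit of this assay, reported for compound 1 as > 10000 nM. Compound 3 `CC(F)(F)c1ncncc1-c1nc2cc(F)c(F)cc2n1C1CC1` has not yet been measured; it differs from compound 2 by 1,1-difluoroethyl in place of ethyl on an aromatic carbon. Among the measured compounds shown here, no measured pair shows what this change does, so the step from compound 2 to compound 3 in this assay is expected to be small, a 1.9-fold higher number from compound 2 to compound 3 (0.27 log units; within the scatter), with a slight weakening seen as somewhat more likely than a gain. Compound 3 is expected to give 15 nM, within 4 nM to 60 nM.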

Compound 3, half-maximal inhibitory concentration: 50 nM
The estimate for compound 3 lay 3.3-fold (0.52 log units) below the measured number; the measured number falls inside the stated range.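

In this assay, placing 1,1-difluoroethyl instead of ethyl on this aromatic carbon gives a 6.3-fold higher number from compound 2 to compound 3 (0.80 log units; beyond the scatter), so inhibition weakens but is not lost. Among these compounds, this is the first measured sign that the group at this position affects the read-out, and that the two fluorines added here are not neutral in this pair. Nothing shown gives a cause for this step. Still open, from the compounds shown here alone, is how a methyl, a longer chain such as propyl, or an amine would fare at this position. Also open, going by these compounds, is whether 1-fluoroethyl, with a single fluorine, would fall closer to ethyl or to 1,1-difluoroethyl.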